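A few compounds are considered here, and "the series" means these few. Any claim that something is new, unique, unknown or untested is made for them only; others in the source may bear on it.

Working notes on the series. The shared core of compound 1 `CC(C)n1ncc2c(C(=O)Nc3cccc(C(N)=O)c3)cc(-c3cccs3)nc21` and compound 2 `CC(C)n1ncc2c(NC(=O)c3ccc(F)cc3)cc(-c3cccs3)nc21` is retained throughout; the two differ only in the amide-linked aryl group. In an ADME assay on LLC-MK2 cells (Macaca mulatta) for cytotoxicity, read by spectrophotometry and crystal violet staining, with a stated time of 4 days (a lower number here means that less compound is tolerated, a higher number that more compound is tolerated), compound 1 gives 25000 nM, and compound 2 gives 50000 nM; the two numbers lie within the scatter of each other, so no ranking between them is drawn. Compound 3 `CC(C)n1ncc2c(C(=O)Nc3ccccn3)cc(-c3cccs3)nc21` has not yet been measured. It differs from compound 1 by pyridin-2-yl in place of 3-carbamoylphenyl on an amide-type nitrogen. Among the compounds with values here, no step between measured compounds is available, so the effect of this change is unknown. With only two measured points that sit within the scatter of each other, the expectation is that the step of a 1.2-fold higher number from compound 1 to compound 3 (0.08 log units; within the scatter) is small, in either direction, and not beyond the scatter. Compound 3 is accordingly estimated at 30000 nM, with a range from 10000 nM to 80000 nM in this assay.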

Compound 3, half-maximal cytotoxic concentration: > 200000 nM
Compound 3 ended at the assay's limit (the forecaster's own chance of this, stated with the estimate: 25%); middle value at least 6.6-fold (0.82 log units) away from the limit.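

Pyridin-2-yl in place of 3-carbamoylphenyl on an amide-type nitrogen gives an at least 8.0-fold higher number from compound 1 to compound 3 (0.90 log units; beyond the scatter) in this assay, the first single-place step in the series, and it shows that this position can move the number beyond the scatter. For compound 3, > 200000 nM is a limit of the assay and not a number. The step therefore fixes a direction and a lower bound, not a size: the limit of > 200000 nM in this assay, at which 1 of the 3 values shown sits.

The change removes the carbamoyl group and brings in a ring nitrogen at once, and the compounds shown do not separate these two parts of the exchange. On these data alone, how a plain phenyl or a pyridin-3-yl on the same amide-type nitrogen would read in this assay stays open.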